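Ethoxycarbonyl for 4-chlorophenyl on the shared core

A few compounds are considered here, and "the series" means these few. Any claim that something is new, unique, unknown or untested is made for them only; others in the source may bear on it.

Of the compounds shown here, two have been measured: compound 1 `Nc1nc(O)c2c(n1)n(C1OC(CO)[C@@H](O)[C@H]1O)c(=O)n2Cc1ccc(Cl)cc1` and compound 2 `C=CCn1c(=S)n(COCCO)c2nc(N)nc(O)c21`. In a functional assay on the whole organism (B cells) with Mus musculus as the target (a higher number here means a larger maximal response, a lower number a smaller maximal response), compound 1 gives 15%, and compound 2 gives 9%, a gap within the scatter, so the two cannot be told apart on these numbers. For the measured compounds named here, no step between measured compounds that differ in one place is available. Compound 3 `CCOC(=O)Cn1c(=O)n(C2OC(CO)[C@@H](O)[C@H]2O)c2nc(N)nc(O)c21` differs from compound 1 by ethoxycarbonyl in place of 4-chlorophenyl on a saturated chain carbon bound to an aromatic nitrogen. Going by the values given here, with no comparable step in hand, the expected change is none beyond the scatter, in no settled direction: a number 2 percentage points lower from compound 1 to compound 3 (within the scatter). Compound 3 is estimated at 13%, with a range from 5% to 25%.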

Compound 3, largest response reached (reported as maximal response), in percent of the reference or control that the assay uses: 86%
Compound 3: the middle estimate sits 73 percentage points below what was measured, and the stated range ends below it.
By their numbers in this assay, from the lowest: compounds 2 and 1 (each within the scatter of the next); then compound 3.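

In this assay, this position responds strongly to the change: ethoxycarbonyl in place of 4-chlorophenyl on a saturated chain carbon bound to an aromatic nitrogen gives a number 71 percentage points higher from compound 1 to compound 3 (beyond the scatter). For the compounds shown here, this is the first step that can be read, and it shows that the group here can set the size of the maximal response on the shared core. No measurement at hand accounts for the gain.

A single step cannot separate the loss of 4-chlorophenyl from the entry of ethoxycarbonyl. Going by these compounds, whether a carboxylic acid, a primary amide or a longer chain ending in the ester would hold the response remains open.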